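The source may report more compounds than this note shows. Statements on the series, on what has been measured and on what is new or still open speak of the compounds shown alone.

Measured compounds:
compound 2, `NC(=O)c1cnc2ccc(-c3cccnc3)cc2c1NC1CCCC1`: 137 nM
compound 1, `C[C@@H](Nc1ccnc2ccc(-c3cccnc3)cc12)c1ccc(Cl)cc1`: a limit only, > 30000 nM

Among the compounds with values here, in an assay on HT-29 cells for inhibition of Serine-protein kinase ATM (Homo sapiens), read by fluorescence, with a stated time of 1 h (a higher number here means a weaker inhibitor, a lower number a stronger inhibitor), compound 2 gives 137 nM, and this is the only number in the set. For compound 1 the assay reports a limit and no number, > 30000 nM; this is the case described by the limit of > 30000 nM in this assay, at which 1 of the 2 values shown sits. Within the data shown here, compound 2 therefore stands as the sole reference point, with no measured step to weigh it against.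

Compound 3, `C[C@H](Nc1c(C(N)=O)cnc2ccc(-c3cccnc3)cc12)C1CCOCC1`, is not yet measured. It differs from compound 2 by 1-(oxan-4-yl)ethyl in place of cyclopentyl on a nitrogen on an aromatic ring. With no measured step of this kind in the set, the direction can only be guessed from the structural change; a moderate gain is expected, larger than the usual scatter but not by much. The step from compound 2 to compound 3 is estimated as a 2.5-fold lower number from compound 2 to compound 3 (0.40 log units; beyond the scatter). For compound 3 the expected value is 55 nM, within 15 nM to 250 nM.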

Compound 3, half-maximal inhibitory concentration: 168 nM
For compound 3 the middle estimate is 3.1-fold (0.48 log units) below the measured one; the range from low to high includes it.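

At the nitrogen on an aromatic ring, 1-(oxan-4-yl)ethyl in place of cyclopentyl gives a 1.2-fold higher number from compound 2 to compound 3 (0.09 log units; within the scatter) in this assay, so the two groups stand level here. Within the data shown here, this position therefore accepts a six-membered non-aromatic ring with 1 hetero atom, carried on an ethyl link with a defined stereocentre, as well as a five-membered ring of carbon only, and this is the first step read at this place. Nothing measured in the set bears on why these two groups read alike.

Going by these compounds, it remains open whether the ring oxygen or the ethyl link counts on its own, and how the other stereoisomer of compound 3 reads. Also open, on these data alone, is how a piperidine ring or a group carrying a carboxylic acid reads on this nitrogen.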